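Methoxyphenyl isomer swap on the thiourea nitrogen

The source may hold more compounds than are shown below. What is called first, only, known or untested is meant among the compounds shown, and "the series" means these compounds.

In a functional assay on MKN-74 cells (Homo sapiens) for antiproliferative activity, with a stated time of 24 h (a lower number here means a stronger inhibitor, a higher number a weaker inhibitor), compound 1 `NC(=O)c1c(NC(=O)c2ccccc2Cl)sc2c1CCN(Cc1ccccc1F)C2` gives 12900 nM and compound 2 `NC(=O)c1c(NC(=O)c2ccccc2Cl)sc2c1CCN(C(=S)Nc1cccc3ccccc13)C2` gives 20700 nM. Compound 3 `COc1ccccc1NC(=S)N1CCc2c(sc(NC(=O)c3ccccc3Cl)c2C(N)=O)C1` gives 35200 nM, the highest of the three numbers: the step of a 2.7-fold higher number from compound 1 to compound 3 (0.44 log units; beyond the scatter) lies beyond the scatter, whereas the step of a 1.7-fold higher number from compound 2 to compound 3 (0.23 log units; within the scatter) does not. Compound 4 `COc1ccc(NC(=S)N2CCc3c(sc(NC(=O)c4ccccc4Cl)c3C(N)=O)C2)cc1` differs from compound 3 by 4-methoxyphenyl in place of 2-methoxyphenyl on an amide-type nitrogen. Going by the values given here, only the step from compound 2 to compound 3 bears on this amide-type nitrogen, and it stayed within the scatter although one aromatic group was replaced by another; the step from compound 1 to compound 3 sits on the amine nitrogen in a ring. No step beyond the scatter is therefore expected for compound 4 in this assay, a 1.2-fold lower number from compound 3 to compound 4 (0.07 log units; within the scatter). Compound 4 is estimated at 30000 nM, within 12000 nM to 75000 nM.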

Compound 4, half-maximal inhibitory concentration: 19600 nM
Estimate against measurement, compound 4: 1.5-fold (0.18 log units) above; the measured number falls inside the stated range.
By their numbers in this assay, from the lowest: compounds 1, 4, 2 and 3 (each within the scatter of the next, the first and the last beyond it).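

Moving the methoxy group, from 2-methoxyphenyl to 4-methoxyphenyl on the amide-type nitrogen, is the first swap at this position between groups of the same atoms, and in this assay it gives a 1.8-fold lower number from compound 3 to compound 4 (0.25 log units; within the scatter) as its result. The step of a 1.1-fold lower number from compound 2 to compound 4 (0.02 log units; within the scatter) shows the 4-methoxyphenyl and naphthalen-1-yl groups also not separated here. On the amine nitrogen in a ring, a 2.7-fold higher number from compound 1 to compound 3 (0.44 log units; beyond the scatter) is not matched by a 1.5-fold higher number from compound 1 to compound 4 (0.18 log units; within the scatter) in this set. No measurement bears on the reason for these numbers.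

As far as these compounds go, whether a carboxylic acid or an amine in place of the methoxy group would move the number beyond the scatter remains open. So does whether any group on this nitrogen separates clearly from 4-methoxyphenyl.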